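This account rests on a few compounds, and the source may have more. Where it says the series, first, only, none or still open, it means among the compounds named here.

Compound 1 `Cc1cc(=O)c2c(O)c(CN3CCN(C(=O)OC(C)(C)C)CC3)c(O)c([C@H]3CCN(C)C[C@H]3O)c2o1`: 16%
Compound 2 `Cc1cc(=O)c2c(O)c(CN3CCC(Cc4ccccc4)CC3)c(O)c([C@H]3CCN(C)C[C@H]3O)c2o1`: 17%
Compound 3 `Cc1oc2c([C@H]3CCN(C)C[C@H]3O)c(O)cc(O)c2c(=O)c1C(O)c1cccc(Cl)c1`: 5%

These three compounds were tested in a functional assay on MCF7 cells (Homo sapiens) for inhibition, read by MTT assay, with a stated time of 48 h, tested at 10 uM; on this read-out lower numbers stand for less inhibition of growth and higher numbers for more inhibition of growth at the one concentration tested. Compound 3 gives 5%, the lowest of the three numbers. Its distance to compound 1 and its distance to compound 2 both lie beyond the usual scatter, while those two compounds lie within the scatter of each other. All three numbers sit at the low end of the scale, so growth of these cells is inhibited little at the concentration tested.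

The next compound to consider is compound 4 `Cc1oc2c([C@H]3CCN(C)C[C@H]3O)c(O)cc(O)c2c(=O)c1C(O)c1c(Cl)cccc1Cl`. It differs from compound 3 in one place: 2,6-dichlorophenyl in place of 3-chlorophenyl on a saturated chain carbon bound to an aromatic carbon and an oxygen on a saturated carbon. In words, 2,6-dichlorophenyl stands in place of 3-chlorophenyl on a saturated chain carbon bound to an aromatic carbon and an oxygen on a saturated carbon.

Going by the values given here, no two measured compounds differ in only one place, so the data offer no direct guide to the effect of this change. On these data alone, with compound 3 at 5% as the only close starting point, no step beyond the scatter is expected in this assay, and the direction stays open. The estimated size of the change is a number 3 percentage points higher from compound 3 to compound 4 (within the scatter). For compound 4, the expected value is 8%, with an estimated range from 1% to 20%.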

Compound 4, percent growth inhibition at one concentration: 33%
Beside the measured number, compound 4's estimate is 25 percentage points below it; the whole stated range lies below it.
By their numbers in this assay, from the lowest: compound 3; then compounds 1 and 2 (each within the scatter of the next); then compound 4.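

In this assay, placing 2,6-dichlorophenyl where 3-chlorophenyl stood, on a saturated chain carbon bound to an aromatic carbon and an oxygen on a saturated carbon, gives a number 28 percentage points higher from compound 3 to compound 4 (beyond the scatter). Going by these compounds alone, this is the first comparison here between two compounds that differ in only one place, and it shows that the growth-inhibition number responds to the aromatic group at this position, which the earlier compounds could not show. Nothing available explains the rise, so the result records an effect without revealing its cause.

The step changes the number of chlorine atoms and their placement on the ring together, so it cannot tell which of the two matters, or whether both do. Compounds carrying a plain phenyl group, or a methoxy group or an amine on the ring in place of chlorine, would help show whether chlorine itself is needed, and whether the number can climb higher than in compound 4, which gives 33%.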